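The source may hold more compounds than are shown below. What is called first, only, known or untested is meant among the compounds shown, and "the series" means these compounds.

Measured so far in a functional assay on HMEC-1 cells (Homo sapiens) for antiproliferative activity, read by cell counting, with a stated time of 4 days; on this read-out higher numbers stand for weaker inhibition and lower numbers for stronger inhibition:
compound 1 `CC(Nc1ccccc1Oc1ccc(Cl)cc1)=C1C(=O)CC(c2ccccc2)CC1=O` gives 260 nM
compound 2 `COc1cc(Oc2ccccc2NC(C)=C2C(=O)CC(c3ccccc3)CC2=O)ccc1N` gives 29 nM
compound 3 `CC(Nc1ccccc1Oc1cccc(N)c1)=C1C(=O)CC(c2ccccc2)CC1=O` gives 41 nM

Compound 2 has the lowest number of the three, though its gap to compound 3 is within the scatter, so those two cannot be told apart. Compound 4 `CC(Nc1ccccc1Oc1ccc(C(C)O)cc1)=C1C(=O)CC(c2ccccc2)CC1=O` differs from compound 2 by 4-(1-hydroxyethyl)phenyl in place of 4-amino-3-methoxyphenyl on an oxygen on an aromatic ring. Within the data shown here, the steps that bear on this place are a 9.0-fold lower number from compound 1 to compound 2 (0.95 log units; beyond the scatter) and a 6.3-fold lower number from compound 1 to compound 3 (0.80 log units; beyond the scatter), both modest and both toward lower numbers when an amino-bearing ring replaced 4-chlorophenyl; the step of a 1.4-fold higher number from compound 2 to compound 3 (0.15 log units; within the scatter) stayed within the scatter. Among the measured compounds shown here, no measured compound carries 4-(1-hydroxyethyl)phenyl, so its effect is unknown. Because compound 2 sits at 29 nM and compound 4 lacks the 4-amino-3-methoxyphenyl, a modest move toward a higher number is expected, a 2.8-fold higher number from compound 2 to compound 4 (0.44 log units; beyond the scatter). Compound 4 is therefore estimated at 80 nM, within 25 nM to 300 nM.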

Compound 4, half-maximal inhibitory concentration: 140 nM
Compound 4: the middle estimate sits 1.8-fold (0.24 log units) below what was measured; the range from low to high includes it.
By their numbers in this assay, from the lowest: compounds 2 and 3 (each within the scatter of the next); then compounds 4 and 1 (each within the scatter of the next).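

In this assay, the rings carrying an amino group stay ahead of 4-(1-hydroxyethyl)phenyl on this oxygen, with a 4.8-fold higher number from compound 2 to compound 4 (0.68 log units; beyond the scatter) and a 3.4-fold higher number from compound 3 to compound 4 (0.53 log units; beyond the scatter). Replacing chloro with 1-hydroxyethyl on the aromatic carbon gives a 1.9-fold lower number from compound 1 to compound 4 (0.27 log units; within the scatter), so that swap cannot be told apart from no change. No evidence is available to explain these steps. On these data alone, it remains open whether the amino group alone accounts for the lower numbers, which a plain 4-aminophenyl ring would test. As far as these compounds go, it is also open how a carboxylic acid or a longer chain would compare with 1-hydroxyethyl.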